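This account rests on a few compounds, and the source may have more. Where it says the series, first, only, none or still open, it means among the compounds named here.

Compound 1 `CC(C)(C)NCc1c(C(=O)O)nn(-c2ccccc2)c1-c1ccccc1` is the starting point of this small set. In a functional assay on 786-0 cells (Homo sapiens) for inhibition, read by sulforhodamine B assay, with a stated time of 48 h (on this read-out lower numbers stand for stronger inhibition of growth and higher numbers for weaker inhibition of growth), compound 1 gives only a limit, > 716000 nM. Compound 2 `Cc1ccc(-c2c(CNC(C)(C)C)c(C(=O)O)nn2-c2ccccc2)cc1` differs from compound 1 by methyl in place of hydrogen on an aromatic carbon, and that change gives a step that the two limits leave unreadable from compound 1 to compound 2. In this assay compound 2 gives only a limit, > 688000 nM. Compound 3 `CC(C)(C)NCc1c(C(=O)O)nn(-c2ccc(Cl)cc2)c1-c1ccccc1` differs from compound 1 by chloro in place of hydrogen on an aromatic carbon, which is also how the core of compound 3 differs from the core of compound 1; that change gives a step that the two limits leave unreadable from compound 1 to compound 3. In this assay compound 3 gives only a limit, > 652000 nM. Compound 4 `Cc1ccc(-c2c(CNC(C)(C)C)c(C(=O)O)nn2-c2ccc(Cl)cc2)cc1` differs from compound 3 by methyl in place of hydrogen on an aromatic carbon, the same change as from compound 1 to compound 2, at the same place. Since every measured value sits at a limit, (the limit of > 652000 nM in this assay, at which 1 of the 3 values shown sits), the limit of > 688000 nM in this assay, at which 1 of the 3 values shown sits, and (the limit of > 716000 nM in this assay, at which 1 of the 3 values shown sits), the earlier step cannot be read, so the step expected in this assay is a step that the limit leaves unreadable from compound 3 to compound 4. Compound 4 is expected to give 700000 nM, most likely again only a limit.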

Compound 4, concentration for 50% growth inhibition: > 629000 nM
Compound 4: only a limit was reported (the forecaster's own chance of this, stated with the estimate: 85%); the middle value is on the limit's open side.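

Compound 2, compound 3 and compound 4 all give only limits, so neither step to compound 4 can be read. As far as these compounds go, whether methyl or chloro changes growth inhibition at all stays open across these four compounds.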